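Replacing 1H-pyrazol-1-yl with propoxy in compound 2

The source may report more compounds than this note shows. Statements on the series, on what has been measured and on what is new or still open speak of the compounds shown alone.

In an ADME assay on a cell-free system (serum, Bos taurus) for protein binding, compound 2 `O=C(NNS(=O)(=O)c1ccccc1F)c1cccc(-n2cccn2)c1` gives 36.2%, while compound 1 `O=C(NNS(=O)(=O)c1ccccc1F)c1cc(F)cc(-n2cccn2)c1` gives 67.2%. Going by the values given here, these two values lie within the scatter of each other, so the pair sets no order, and compound 2 stands level with its only measured neighbour.

The next analogue, compound 3 `CCCOc1cccc(C(=O)NNS(=O)(=O)c2ccccc2F)c1`, keeps the shared core and carries propoxy in place of 1H-pyrazol-1-yl on an aromatic carbon. Among the compounds with values here, no measured step covers this exchange. The only one available is a 1.9-fold higher unbound fraction from compound 1 to compound 2 (0.29 log units; within the scatter), which puts hydrogen in place of fluoro and stays within the scatter. It therefore bears on the new change only indirectly, as a guide to how small a single substitution can be in this short series.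

On that slender basis, a large move in this assay is not expected, and the direction remains uncertain. The expected step is a 1.3-fold lower unbound fraction from compound 2 to compound 3 (0.11 log units; within the scatter), which would not stand beyond the scatter. The estimated binding of compound 3 is 50%, with an expected range from 25% to 78%.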

Compound 3, plasma protein binding: 71%
Estimate against measurement, compound 3: 1.7-fold (0.24 log units) (unbound fraction) above; low and high end bracket the measured number.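

At this place, on an aromatic carbon of a six-membered aromatic ring of carbon only and meta to a large group, the exchange of 1H-pyrazol-1-yl for propoxy gives a 2.2-fold lower unbound fraction from compound 2 to compound 3 (0.34 log units; beyond the scatter) in this assay. Going by these compounds alone, this is the first step to stand beyond the scatter, so the position responds measurably to this change, although the step is modest and the earlier exchange of fluoro for hydrogen did not establish such a response. Within the data shown here, the exchange alters the ring, the heavy-atom count and the hydrogen-bond acceptor count at once, so the single pair cannot separate these features, and no measurement available here accounts for the step.

The compounds shown leave open whether a methoxy group or a longer chain such as butoxy at this place would continue the step seen with propoxy, or whether an amine or a carboxylic acid there would reverse it. They also leave open whether fluoro, as carried by compound 1, would have a comparable effect on the propoxy analogue compound 3.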